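The compounds below may be only part of what the source reports. "The series", "measured", "known", "first", "only" and "open" are said of these compounds alone.

Compound 1 `CCCCc1nc(=O)c(S(=O)(=O)c2ccc(-c3cccnc3)cc2)c(O)n1-c1c(OC)cccc1OC` gives 3% in an ADME assay on microsomes from liver (Rattus norvegicus) for metabolic stability, using NADPH, with a stated time of 10 min; a lower number here means that less of the compound is left, a higher number that more of the compound is left.
Compound 2 `CCCCc1[nH]c(=O)c(S(=O)(=O)c2ccc(-n3ccccc3=O)cc2)c(O)c1-c1c(OC)cccc1OC` gives 100% in this assay.
Compound 3 `CCCCc1[nH]c(=O)c(S(=O)(=O)c2ccc(-n3cc(Cl)ccc3=O)cc2)c(O)c1-c1c(OC)cccc1OC` gives 72% in this assay.

Compound 1 stands lowest of the three, beyond the scatter below both compound 3 and compound 2. Compound 4 `CCCCc1nc(=O)c(S(=O)(=O)c2ccc(C)cc2)c(O)n1-c1c(OC)cccc1OC` differs from compound 1 by methyl in place of pyridin-3-yl on an aromatic carbon. Among the compounds with values here, the only measured step, a number 28 percentage points lower from compound 2 to compound 3 (beyond the scatter), concerns a different change on a different ring, so it does not bear directly on this one; no measured pair covers swapping pyridin-3-yl for methyl. Starting from the very low number of compound 1, only a rise is possible, and the expected step is a number 12 percentage points higher from compound 1 to compound 4 (beyond the scatter), with wide uncertainty. Compound 4 is therefore estimated at 15% in this assay, between 2% and 45%.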

Compound 4, percent of the compound remaining: 74%
Estimate against measurement, compound 4: 59 percentage points below; the measured number lies above the stated range.
By their numbers in this assay, from the lowest: compound 1; then compounds 3 and 4 (each within the scatter of the next); then compound 2.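

In this assay, methyl in place of pyridin-3-yl gives a number 71 percentage points higher from compound 1 to compound 4 (beyond the scatter), a large rise from one change on the aromatic ring para to a large group. On the core of compound 1, the group at this place therefore has a strong say in how much compound is left. Nothing shown here gives the reason for the rise. From the compounds shown here alone, it remains open whether a plain phenyl, an ethyl chain or an amine at this place would behave more like methyl or more like pyridin-3-yl.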